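A few compounds are considered here, and "the series" means these few. Any claim that something is new, unique, unknown or untested is made for them only; others in the source may bear on it.

Working notes on the series. Compound 1 `Cc1nn(-c2ncnc3nc[nH]c23)c2c1C(C(=O)NCc1ccc(F)cc1)CC(=O)N2` gives 4 nM in a functional assay on HEK293 cells for agonist activity at G-protein coupled receptor 39 (Homo sapiens), read by scintillation proximity assay and inositol phosphate accumulation, with a stated time of 75 min, in the presence of a further agent that is not named here; a higher number here means that more compound is needed for the effect, a lower number that less compound is needed. Compound 2 `C/C(=N\NC(=O)c1cc2ccccc2cc1O)c1ccc(N)cc1` gives 1100 nM in this assay. Compound 3 `Cc1noc(C)c1COC1CC(=O)Nc2c1c(C)nn2-c1ncnc2nc[nH]c12` gives 5 nM in this assay; of the three numbers it is the second highest, its nearest neighbour being compound 1 at a difference within the scatter, while compound 2 lies far beyond the scatter on the high side.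

Compound 4 `Cc1nn(-c2ncnc3nc[nH]c23)c2c1C(OCC(C)C)CC(=O)N2` is not yet measured. It differs from compound 3 in one place: isopropyl in place of 3,5-dimethyl-1,2-oxazol-4-yl on a saturated chain carbon bound to an oxygen on a saturated carbon. Among the compounds with values here, no pair of measured compounds shares this change, so the step is uncharted. A moderate shift toward a higher number is expected, a 3.0-fold higher number from compound 3 to compound 4 (0.48 log units; beyond the scatter). Compound 4 is estimated at 15 nM in this assay, with a range from 3 nM to 80 nM.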

Compound 4, half-maximal effective concentration: 4 nM
The estimate for compound 4 lay 3.8-fold (0.57 log units) above the measured number, and the stated range covers the measured number.
By their numbers in this assay, from the lowest: compounds 1, 4 and 3 (each within the scatter of the next); then compound 2.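

In this assay, replacing 3,5-dimethyl-1,2-oxazol-4-yl with isopropyl on this saturated chain carbon gives a 1.3-fold lower number from compound 3 to compound 4 (0.10 log units; within the scatter). At this position, the five-membered aromatic ring and its hetero atoms are therefore not needed for a value in this range, since the entering group has no ring and no hydrogen-bond acceptors. No measured evidence explains why the two groups read alike.

Still open, going by these compounds, is how an amine or a carboxylic acid at the end of the chain would read in this assay. On these data alone, a longer chain, such as n-hexyl in place of isobutyl, is equally open.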